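Compound 2 and Its Ring-Carbon Stereoisomer, Compound 3

The compounds below may be only part of what the source reports. "The series", "measured", "known", "first", "only" and "open" are said of these compounds alone.

- compound 1 `Cc1cn([C@H]2C[C@H](CC3=CC(=O)C(=O)C=C3)[C@@H](CO[Si](C)(C)C(C)(C)C)O2)c(=O)[nH]c1=O`: no result reported
- compound 2 `COc1ccc(C2([C@H]3C[C@H](n4cc(C)c(=O)[nH]c4=O)O[C@@H]3CO[Si](C)(C)C(C)(C)C)SCCCS2)cc1OC`: 4070 nM

Going by the values given here, in a functional assay on HCT-15 cells (Homo sapiens) for inhibition, read by sulforhodamine B assay, with a stated time of 48 h (a higher number here means a weaker inhibitor of growth, a lower number a stronger inhibitor of growth), compound 2 stands at 4070 nM as the only number available. Compound 1 has no reported result, so compound 2 cannot be ranked against anything. Compound 3 `COc1ccc(C2([C@H]3C[C@@H](n4cc(C)c(=O)[nH]c4=O)O[C@@H]3CO[Si](C)(C)C(C)(C)C)SCCCS2)cc1OC` is the next to be measured. Its difference from compound 2 is the two compounds have the same atoms and bonds and differ only in configuration as drawn: 1 of 3 stereo elements differ; a stereocentre at a saturated ring carbon is drawn R in compound 2 and S in compound 3 and nothing else: a stereocentre at a saturated ring carbon is drawn R in compound 2 and S in compound 3. Among the compounds with values here, no measured pair shows what such a change does, so no step beyond the usual scatter, in either direction, is expected in this assay for now. The expected move is a 1.1-fold higher number from compound 2 to compound 3 (0.04 log units; within the scatter) and it remains only an estimate. Compound 3 is estimated at 4500 nM with an expected range from 1800 nM to 11000 nM on this reading.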

Compound 3, concentration for 50% growth inhibition: 9120 nM
Compound 3: middle estimate off by 2.0-fold (0.31 log units), on the low side; low and high end bracket the measured number.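

In this assay, going by these compounds alone, the configuration at this saturated ring carbon turns out to matter, which no earlier compound could show: the change from R to S gives a 2.2-fold higher number from compound 2 to compound 3 (0.35 log units; beyond the scatter). The step is modest, and the R form as drawn, compound 2, is the stronger inhibitor of growth of this pair. Since nothing else separates the two, the step can be put down to configuration alone, because of this one fact: the fact that compounds 2 and 3 differ only in the configuration as drawn

On these data alone, this remains a single pair, so it is open whether the same inversion would give a similar step in compounds carrying a free hydroxyl group in place of the silyl ether, or an amine on the shared core. Compound 1 has no number, so it adds nothing to this comparison.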